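A few compounds are considered here, and "the series" means these few. Any claim that something is new, unique, unknown or untested is made for them only; others in the source may bear on it.

Compound 1 `O=C(CNc1nc(N2CCc3ccccc3C2)nc2ccccc12)NCc1ccccc1`: 29400 nM
Compound 2 `CCN(CC)c1nc(SCC(=O)Nc2ccccc2)c2ccccc2n1`: > 100000 nM
Compound 3 `O=C(CNc1nc(N2CCCC2)nc2ccccc12)Nc1ccc2ccccc2c1`: 59900 nM

In an ADME assay on HEK-293T cells (Homo sapiens) for cytotoxicity, read by CCK-8 assay, with a stated time of 48 h (on this read-out lower numbers stand for higher toxicity in this test and higher numbers for lower toxicity in this test), compound 2 gives only a limit of the assay (> 100000 nM) and not a number. Compound 4 `CCN(CC)c1nc(SCC(=O)NCc2ccccc2)c2ccccc2n1` is compound 2 with one change (benzyl in place of phenyl on an amide-type nitrogen): benzyl in place of phenyl on an amide-type nitrogen. Among the compounds with values here, no measured pair isolates this change. Compound 1, which also has benzyl on an amide-type nitrogen but a different core, gives 29400 nM in this assay. On that single comparison a modest step toward lower numbers is expected, and a result that stays at the limit would be no surprise. The expected step (an at least 1.2-fold lower number from compound 2 to compound 4 (0.09 log units; that floor lies within the scatter)) is small. Compound 4 is estimated at 80000 nM (range 40000 nM to 150000 nM).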

Compound 4, half-maximal cytotoxic concentration: > 100000 nM
Compound 4: no number, only a limit; the forecaster's own chance of this, stated with the estimate: 40%; at least 1.2-fold (0.09 log units) between middle value and limit.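

Within the data shown here, compound 2 and compound 4 both stand at a limit and not at a number, so no step between them can be read: the limit of > 100000 nM in this assay, at which 2 of the 4 values shown sit. The compounds shown leave open whether in this assay benzyl in place of phenyl on an amide-type nitrogen changes the value at all.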